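Pyrazoline amide series: amine swap at the chain carbon

A few compounds are considered here, and "the series" means these few. Any claim that something is new, unique, unknown or untested is made for them only; others in the source may bear on it.

Measured so far:
compound 1 `C=CCN(CC=C)CC(=O)N1N=C(C)CC1c1cc(Br)ccc1O` — 3090 nM
compound 2 `CCCNCC(=O)N1N=C(c2cc3ccccc3oc2=O)CC1c1ccccc1` — 7270 nM

In a functional assay on PC-3 cells (Homo sapiens) for cytotoxicity, read by MTT assay, with a stated time of 48 h (a higher number here means a weaker inhibitor, a lower number a stronger inhibitor), compound 2 gives the higher of the two numbers; compound 1 sits lower, and that gap lies beyond the usual scatter. Compound 3 `O=C(CN1CCC(O)CC1)N1N=C(c2cc3ccccc3oc2=O)CC1c1ccccc1` is not yet measured. It differs from compound 2 in one place: 4-hydroxypiperidin-1-yl in place of propylamino on a saturated chain carbon bound to a carbonyl carbon. Among the compounds with values here, no measured pair in this set shows this kind of change, so there is no step to lean on. A step from compound 2 to compound 3 of no more than the scatter is expected, in either direction, giving an estimate of a 1.2-fold lower number from compound 2 to compound 3 (0.08 log units; within the scatter). Compound 3 is expected to give about 6000 nM, within 2500 nM to 15000 nM.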

Compound 3, half-maximal inhibitory concentration: "not active" (no number reported)
The entry for compound 3 holds no number; the estimate stays without a comparison.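

In this assay, within the data shown here, compound 3 is reported as not active without a number, so no step from compound 2 to compound 3 can be read. From the compounds shown here alone, how 4-hydroxypiperidin-1-yl compares with propylamino on this core stays open. No evidence on hand bears on this result.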